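Notes on the benzyl substituent of compound 1

A few compounds are considered here, and "the series" means these few. Any claim that something is new, unique, unknown or untested is made for them only; others in the source may bear on it.

Compound 1 `Cc1cc(S(=O)(=O)/N=C(\N)n2nccc2-c2ccccc2)c(SCc2ccc(Cl)cc2)cc1Cl` is the reference point of this set. In a functional assay on HCT-116 cells (Homo sapiens) for cytotoxicity, read by MTT assay, with a stated time of 72 h (on this read-out higher numbers stand for weaker inhibition and lower numbers for stronger inhibition), compound 1 gives 7000 nM. Compound 2 `Cc1cc(S(=O)(=O)/N=C(\N)n2nccc2-c2ccccc2)c(SCc2cccc3ccccc23)cc1Cl` gives 7000 nM in this assay, and compound 3 `Cc1cc(-c2ccccc2)n(/C(N)=N/S(=O)(=O)c2cc(C)c(Cl)cc2SCc2cccc(Cl)c2)n1` gives 18000 nM. Compound 1 therefore stands level with compound 2, the two together holding the lowest numbers of the three, while the value of compound 3 is the higher one.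

Among the measured compounds shown here, the one step measured so far, no change at the digits printed from compound 1 to compound 2 (within the scatter), replaces the group on the sulfur-bound chain carbon: naphthalen-1-yl in place of 4-chlorophenyl leaves the number where it was. For the measured compounds named here, no step between compound 1 and compound 3 is tabulated as a single change; their values alone are recorded.

Compound 4 `Cc1ccc(CSc2cc(Cl)c(C)cc2S(=O)(=O)/N=C(\N)n2nccc2-c2ccccc2)cc1` is not yet measured. It differs from compound 1 by methyl in place of chloro on an aromatic carbon, with the difference read one bond further out as 4-chlorobenzyl to 4-methylbenzyl. Going by the values given here, the only step that touches this part of the molecule is the one from compound 1 to compound 2, and it was flat; no measured step swaps chloro for methyl anywhere. The step of no change at the digits printed from compound 1 to compound 4 (within the scatter) is expected to stay within the scatter. Compound 4 is estimated at 7000 nM, within 3500 nM to 14000 nM.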

Compound 4, half-maximal inhibitory concentration: 14000 nM
The estimate for compound 4 lay 2.0-fold (0.30 log units) below the measured number, and the stated range covers the measured number.
By their numbers in this assay, from the lowest: compounds 1, 2, 4 and 3 (each within the scatter of the next, the first and the last beyond it).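

Working notes on the 4-substituent of the benzyl group. In this assay, methyl in place of chloro on the aromatic carbon para to a large group gives a 2.0-fold higher number from compound 1 to compound 4 (0.30 log units; within the scatter). This is the first exchange shown that keeps the benzyl ring and alters only the one group on it, and the position accepts 4-methylbenzyl as well as 4-chlorobenzyl without a step beyond the scatter. Read against the larger aryl group, 4-methylphenyl in place of naphthalen-1-yl gives a 2.0-fold higher number from compound 2 to compound 4 (0.30 log units; within the scatter), so compound 1, compound 2 and compound 4 now form a set of three groups on the sulfur-bound chain carbon with every printed step among them inside the scatter. Nothing available on these compounds offers an explanation for this result.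

Still open, on these data alone, is whether a carboxylic acid or an amine in place of the chloro on the same ring carbon would stay within the scatter of compound 1 at 7000 nM. Also open, as far as these compounds go, is whether a longer chain in place of the benzyl group on the sulfur would leave the number equally undisturbed.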